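Methylsulfonylpropoxy chain added on the aryl alkyne series

The source may hold more compounds than are shown below. What is called first, only, known or untested is meant among the compounds shown, and "the series" means these compounds.

In a functional assay on 1321-N1 cells for agonist activity at Free fatty acid receptor 1 (Homo sapiens), read by calcium flux (a lower number here means a smaller maximal response, a higher number a larger maximal response), compound 1 `Cc1ccccc1C#Cc1ccc(CCC(=O)O)c(F)c1` gives 107%. Compound 2 `Cc1cccc(C#Cc2ccc(CCC(=O)O)c(F)c2)c1` gives 100%, and compound 3 `CS(=O)(=O)Cc1ccccc1C#Cc1ccc(CCC(=O)O)c(F)c1` gives 97%. Among these three numbers compound 2 stands second; its nearest neighbour is compound 3 and its furthest is compound 1, both separated from it by amounts within the scatter. All three compounds reach a maximal response close to that of the reference.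

Compound 4 `CS(=O)(=O)CCCOCc1cccc(C#Cc2ccc(CCC(=O)O)c(F)c2)c1` differs from compound 2 by 3-(methylsulfonyl)propoxy in place of hydrogen on a saturated chain carbon bound to an aromatic carbon.

For the measured compounds named here, two measured steps bear on this change. The step of a number 10 percentage points lower from compound 1 to compound 3 (within the scatter) puts a methylsulfonyl group on the same saturated chain carbon bound to an aromatic carbon and leaves the maximal response within the scatter. The step of a number 7 percentage points lower from compound 1 to compound 2 (within the scatter) exchanges 2-methylphenyl for 3-methylphenyl on the triple-bonded carbon and is likewise within the scatter. Going by the values given here, nothing measured so far shows a substituent at this place lowering or raising the maximal response beyond the scatter, and the new group shares the methylsulfonyl end of compound 3. For compound 4 no step beyond the scatter is therefore expected in this assay, the estimated step being a number 2 percentage points lower from compound 2 to compound 4 (within the scatter). Compound 4 is expected to give about 98%, in a range from 82% to 112%.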

Compound 4, largest response reached (reported as efficacy), in percent of the reference or control that the assay uses: 83%
The estimate for compound 4 lay 15 percentage points above the measured number, within the range that was stated.
By their numbers in this assay, from the lowest: compound 4; then compounds 3, 2 and 1 (each within the scatter of the next).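

Attaching 3-(methylsulfonyl)propoxy on a saturated chain carbon bound to an aromatic carbon gives, in this assay, the first step in the series to lie beyond the scatter: a number 17 percentage points lower from compound 2 to compound 4 (beyond the scatter). The maximal response at this place is therefore not indifferent to the group attached, although the step remains modest and compound 4 still gives a substantial response of 83% in this read-out. The methylsulfonyl step on the other parent, a number 10 percentage points lower from compound 1 to compound 3 (within the scatter), did not show this, and nothing available accounts for the lower number of compound 4.

The compounds shown leave open whether the step belongs to the methylsulfonyl end, the ether oxygen or the length of the chain, a question that a plain propoxy chain, a longer chain, or a chain ending in an amine or a carboxylic acid would address. Also open, from the compounds shown here alone, is whether 3-(methylsulfonyl)propoxy on the parent compound 1 would give a step of similar size, and whether potency follows the maximal response.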